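This account rests on a few compounds, and the source may have more. Where it says the series, first, only, none or still open, it means among the compounds named here.

Compound 2 `Cc1nc(S(C)(=O)=O)ccc1Oc1ncnc(OC2CCN(C(=O)OC(C)(C)C(F)(F)F)CC2)c1F` gives 6.53 nM in a functional assay on isolated protein for inhibition of Glucose-dependent insulinotropic receptor (Homo sapiens), read by HTRF and cAMP accumulation (on this read-out lower numbers stand for an effect already at smaller amounts and higher numbers for an effect only at larger amounts of compound), and stands lowest of the three measured numbers. Compound 1 `Cc1nc(S(C)(=O)=O)ccc1Oc1ncnc(OC2CCN(C(=O)OC3CCC3)CC2)c1F` gives 13.6 nM, and compound 3 `Cc1nc(S(C)(=O)=O)ccc1Oc1ncnc(OC2CCN(C(=O)OC(C)F)CC2)c1F` gives 65.5 nM. All three share the same core and differ only in the group on an oxygen next to a carbonyl group. Compound 4 `Cc1nc(S(C)(=O)=O)ccc1Oc1ncnc(OC2CCN(C(=O)OC3COC3)CC2)c1F` is not yet measured; the change is oxetan-3-yl in place of 1-methyl-1-(trifluoromethyl)ethyl on an oxygen next to a carbonyl group.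

The measured steps at this position were a 2.1-fold lower number from compound 1 to compound 2 (0.32 log units; beyond the scatter), a 4.8-fold higher number from compound 1 to compound 3 (0.68 log units; beyond the scatter) and a 10-fold higher number from compound 2 to compound 3 (1.00 log units; beyond the scatter). The oxetan-3-yl group entering in compound 4 is, like the cyclobutyl of compound 1, a ring at this position, with one hetero atom added; compound 1 sits between compound 2 and compound 3 in the assay. The step from compound 2 is therefore expected to go toward higher numbers, of a size near that from compound 2 to compound 1, and estimated as a 3.4-fold higher number from compound 2 to compound 4 (0.53 log units; beyond the scatter). Compound 4 is expected to give 22 nM, with a range from 8 nM to 60 nM.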

Compound 4, half-maximal effective concentration: 326 nM
The estimate for compound 4 lay 15-fold (1.17 log units) below the measured number; the measured number lies above the stated range.
By their numbers in this assay, from the lowest: compound 2; then compound 1; then compound 3; then compound 4.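

In this assay, oxetan-3-yl in place of cyclobutyl gives a 24-fold higher number from compound 1 to compound 4 (1.38 log units; beyond the scatter), so at this position a four-membered ring alone does not keep the number low, and these two rings part widely once the ring holds a hetero atom. The new group also falls behind both open-chain groups, with a 50-fold higher number from compound 2 to compound 4 (1.70 log units; beyond the scatter) and a 5.0-fold higher number from compound 3 to compound 4 (0.70 log units; beyond the scatter), so 1-fluoroethyl no longer marks the high end of the series. No available measurement gives a reason for this rise.

The compounds shown leave open whether the rise follows the ring oxygen in particular or would return with a nitrogen in the same ring, as in an azetidine. They also leave open how an oxygen in an open chain, as in a 2-methoxyethyl group, would read here.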